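This account rests on a few compounds, and the source may have more. Where it says the series, first, only, none or still open, it means among the compounds named here.

Within the data shown here, compound 2 `Cc1c(Cc2c(F)cccc2F)nc(N(C)C(C)C)[nH]c1=O` is the one member of this set that yields an actual number in an ADME assay on MT4 cells (Homo sapiens) for cytotoxicity, read by MTT assay, with a stated time of 4 days; a higher number here means that more compound is tolerated, a lower number that less compound is tolerated: there compound 2 gives 79000 nM. Compound 1 `O=c1cc(Cc2c(F)cccc2F)nc(N2CCCCCC2)[nH]1` gives only > 78000 nM in this assay, which is a limit of the assay and not a number. Compound 3 `Cc1c(Cc2c(F)cccc2N2CCCC2)nc(N2CCCC2)[nH]c1=O` likewise reaches only a limit in this assay, namely > 70000 nM. Compound 4 `Cc1c(Cc2c(F)cccc2F)nc(N2CCC(C)CC2)[nH]c1=O` differs from compound 2 in one place: 4-methylpiperidin-1-yl in place of isopropyl(methyl)amino on an aromatic carbon. Among the measured compounds shown here, no step between measured compounds is at hand to gauge such a change, and the three measured values all sit close together. The step of a 1.1-fold lower number from compound 2 to compound 4 (0.02 log units; within the scatter) is therefore expected to stay within the scatter, in no clear direction. Compound 4 is expected to give about 75000 nM, most likely between 35000 nM and 160000 nM, with a real chance that only a limit is reported.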

Compound 4, half-maximal cytotoxic concentration: > 75000 nM
Compound 4: no number, only a limit (the forecaster's own chance of this, stated with the estimate: 50%); the middle value sits exactly at the limit.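

Among these compounds, compound 4 reaches only a limit of the assay, > 75000 nM, and no step between compound 2 and compound 4 can be read. The compounds shown leave open whether 4-methylpiperidin-1-yl in place of isopropyl(methyl)amino changes the number in this assay at all.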